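A few compounds are considered here, and "the series" means these few. Any claim that something is new, unique, unknown or untested is made for them only; others in the source may bear on it.

Three compounds sharing one core were tested in an in vitro functional assay on HEK285-7 cells for antagonist activity at prostaglandin D2 receptor 2 (Homo sapiens), read by BRET and beta-arrestin recruitment; on this read-out higher numbers stand for weaker inhibition and lower numbers for stronger inhibition. Compound 1, `Nc1nc(-c2ccc(Cl)cc2)c(CC(=O)O)s1`, gave in this assay a result of > 100000 nM, which is a limit of the assay and not a number. Compound 2, `CCC(c1ccccc1)c1nc(-c2ccc(Cl)cc2)c(CC(=O)O)s1`, gave in this assay likewise a result of > 100000 nM, again a limit rather than a number. For the measured compounds named here, compound 3, `O=C(O)Cc1sc(C(c2ccccc2)c2ccccc2)nc1-c1ccc(F)cc1`, stands apart: in this assay compound 3 gives 77 nM, the only actual number among the three results. The other two results are the limit of > 100000 nM in this assay, at which 2 of the 3 values shown sit. Compound 4, `O=C(O)Cc1sc(C(c2ccccc2)c2ccccc2)nc1-c1ccc(F)c(F)c1`, has not yet been measured. It differs from compound 3 by fluoro in place of hydrogen on an aromatic carbon, so that the 4-fluorophenyl of compound 3 becomes 3,4-difluorophenyl. No measured pair shows a step of this kind, so the shown compounds give no direction for it. The step from compound 3 to compound 4 is therefore expected to be a 1.1-fold lower number from compound 3 to compound 4 (0.04 log units; within the scatter), not beyond the usual scatter. Compound 4 is estimated at 70 nM, within a range from 25 nM to 200 nM.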

Compound 4, half-maximal inhibitory concentration: 43 nM
The estimate for compound 4 lay 1.6-fold (0.21 log units) above the measured number, within the range that was stated.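

Compound 3 and compound 4 form the first pair shown that differs in one place, so this change can now be read in this assay: a 1.8-fold lower number from compound 3 to compound 4 (0.25 log units; within the scatter). The step lies within the usual scatter, so adding a fluoro at this aromatic carbon keeps the result in the same range, and this single pair supports no claim of a gain or a loss. Nothing measured here gives a reason for the size of this step.

Going by these compounds, it remains open whether a methoxy group, a trifluoromethyl group or an amine at this same carbon would also leave the number within the scatter. Compound 1 and compound 2 cannot settle this, as each differs from compound 3 in more than one place and gives a limit of the assay, not a number: the limit of > 100000 nM in this assay, at which 2 of the 4 values shown sit.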